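Working notes: cyclobutyl amide in place of fluoropiperidinyl urea

This account rests on a few compounds, and the source may have more. Where it says the series, first, only, none or still open, it means among the compounds named here.

Measured so far:
Compound 1, `CC1CCCCC1C(=O)N1CC(c2nc(-c3cccc(F)c3)no2)C1`: > 10000 nM
Compound 2, `Cc1cccc(-c2noc(C3CN(S(=O)(=O)c4cccc(C)c4)C3)n2)c1`: 650 nM
Compound 3, `O=C(N1CCC(F)CC1)N1CC(c2nc(-c3cccc(Cl)c3)no2)C1`: > 10000 nM

In an assay on HEK293 cells for negative allosteric modulation of metabotropic glutamate receptor 5 (Homo sapiens), read by FLIPR (a lower number here means a stronger inhibitor, a higher number a weaker inhibitor), compound 1 returns only a limit, > 10000 nM. Compound 2 gives a number, 650 nM. Compound 3 likewise returns only a limit, > 10000 nM. Compound 3 therefore stands only at a limit in this assay, and it shares that position with compound 1 at the limit of > 10000 nM in this assay, at which 2 of the 3 values shown sit. Within the data shown here, no two measured compounds differ in a single place, so no measured step exists in this set.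

Compound 4, `O=C(C1CCC1)N1CC(c2nc(-c3cccc(Cl)c3)no2)C1`, differs from compound 3 by cyclobutyl in place of 4-fluoropiperidin-1-yl on a carbonyl carbon. Compound 1, also a cycloalkyl amide, sits at the limit as well. The step from compound 3 to compound 4 is expected to be a step that the limit leaves unreadable from compound 3 to compound 4, none beyond the scatter. Compound 4 is expected at 15000 nM, with a range from 3000 nM to 60000 nM.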

Compound 4, half-maximal inhibitory concentration: 1500 nM
Compound 4: middle estimate off by 10-fold (1.00 log units), on the high side; the measured number lies below the stated range.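

In this assay, the group on the carbonyl carbon alone decides whether a measurable number appears: cyclobutyl in place of 4-fluoropiperidin-1-yl gives an at least 6.6-fold lower number from compound 3 to compound 4 (0.82 log units; beyond the scatter). Among these compounds, this is the first single-place step, and it shows that this position responds to change with the rest of the structure held constant. Compound 3 holds only a limit, so the full size of the step stays unknown: the limit of > 10000 nM in this assay, at which 2 of the 4 values shown sit.

On these data alone, how far the gain depends on ring size stays open, and cyclopropyl or cyclopentyl on the same carbonyl carbon would bear on that. Whether an open chain such as isobutyl serves as well is also unresolved.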